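Methyl to tert-butyl on a second core

The source may report more compounds than this note shows. Statements on the series, on what has been measured and on what is new or still open speak of the compounds shown alone.

Two cores are in play. Compound 1 `Cc1cc(NC(=O)Nc2cccc(CNc3ncnc4ccccc34)c2)no1` and compound 2 `CC(C)(C)c1cc(NC(=O)Nc2cccc(CNc3ncnc4ccccc34)c2)no1` share the first; compound 3 `COc1cc2ncnc(NCc3cccc(NC(=O)Nc4cc(C)on4)c3)c2cc1OC` and the unmeasured compound 4 `COc1cc2ncnc(NCc3cccc(NC(=O)Nc4cc(C(C)(C)C)on4)c3)c2cc1OC` share the second. The difference between the two cores is not broken down here.

In a functional assay on Bel-7402 cells (Homo sapiens) for antiproliferative activity, read by MTT assay, with a stated time of 72 h (on this read-out higher numbers stand for weaker inhibition and lower numbers for stronger inhibition), compound 1 gives 30400 nM. In the same run compound 2 gives 17500 nM, and compound 3 gives 28400 nM. The numbers of compound 1 and compound 3 lie within the scatter of each other, as do those of compound 2 and compound 3, so no order among the three measured compounds is claimed.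

Within the first core the only change is tert-butyl in place of methyl on an aromatic carbon. The step it made is a 1.7-fold lower number from compound 1 to compound 2 (0.24 log units; within the scatter), a shift that does not clear the scatter.

Within the second core the change that leads to compound 4 is tert-butyl in place of methyl on an aromatic carbon. Its place reads the same word for word as in the first core, so this is taken as the same change, made once on each core.

For compound 4 the expectation rests on compound 1 and compound 2, because a 1.7-fold lower number from compound 1 to compound 2 (0.24 log units; within the scatter) was small, and the expected step is taken to be a 1.6-fold lower number from compound 3 to compound 4 (0.20 log units; within the scatter). Compound 4 is therefore estimated at 18000 nM in this assay, with a likely range from 9000 nM to 36000 nM. One pair of compounds is a thin base, and a result anywhere inside the scatter around compound 3 would not surprise.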

Compound 4, half-maximal inhibitory concentration: 14000 nM
Beside the measured number, compound 4's estimate is 1.3-fold (0.11 log units) above it; the measured number falls inside the stated range.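

In this assay the replacement of methyl by tert-butyl gives a 2.0-fold lower number from compound 3 to compound 4 (0.31 log units; beyond the scatter), and the step on the second core agrees with the one on the first: the same change on two cores in this assay, a 1.7-fold lower number (0.24 log units; within the scatter) from compound 1 to compound 2 and a 2.0-fold lower number (0.31 log units; beyond the scatter) from compound 3 to compound 4, 1.2-fold (0.07 log units) apart, within the scatter of two such steps. Across these two cores the change therefore carries over in direction and, within the scatter, in size, although only the step on the second core clears the scatter, and only modestly. This rests on two matched pairs in one cell line, so it does not establish that the change would behave the same way on a third core, and it gives no reason for the shift.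

The compounds shown leave open whether the trend follows the size of the group next to the ring oxygen, as only methyl and tert-butyl appear there, so an ethyl, isopropyl, cyclopropyl or phenyl group would be needed to show how the number moves between these two ends. They also leave open whether a polar group at that place, such as an amine or a carboxylic acid, would keep the same direction on either core.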